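Quinazolinyl aminotriazoles: limits so far, one open step

This account rests on a few compounds, and the source may have more. Where it says the series, first, only, none or still open, it means among the compounds named here.

Measured compounds:
compound 1 `Nc1nc(-c2ccccn2)nn1-c1ncnc2ccccc12`; compound 2 `COc1cc2ncnc(-n3nc(-c4ccc(Cl)cc4)nc3N)c2cc1OC`; compound 3 `COc1cc2nc(Cl)nc(-n3nc(-c4ccccn4)nc3N)c2cc1OC`

In an assay on MCF7 cells for inhibition of Serine-protein kinase ATM (Homo sapiens), read by immunofluorescence, with a stated time of 1 h (a lower number here means a stronger inhibitor, a higher number a weaker inhibitor), compound 1 gives > 40000 nM, a limit of the assay and not a number. In this assay compound 2 gives > 40000 nM, again only a limit. Compound 3 gives > 40000 nM in this assay, likewise a limit. For the measured compounds named here, no step between measured compounds can be read, since all three sit at the limit of > 40000 nM in this assay, at which 3 of the 3 values shown sit.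

The open step goes from compound 3 to compound 4 `CCOC(=O)CNc1nc(-n2nc(-c3ccccn3)nc2N)c2cc(OC)c(OC)cc2n1`: ((ethoxycarbonyl)methyl)amino in place of chloro on an aromatic carbon. Compound 3 stands at the limit, so no direction can be drawn from the measured set; nothing in the three values shown speaks for a gain. The pyridinyl-bearing triazole of compound 3 is kept, so the expectation rests on the new group alone. For compound 4 a step of about an at least 1.6-fold lower number from compound 3 to compound 4 (0.20 log units; that floor lies within the scatter) is expected, with a real chance that only a limit is reported again. Compound 4 is estimated at 25000 nM in this assay, within 4000 nM to 40000 nM.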

Compound 4, half-maximal inhibitory concentration: > 40000 nM
Compound 4: no number, only a limit (the forecaster's own chance of this, stated with the estimate: 55%); middle value at least 1.6-fold (0.20 log units) away from the limit.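

No step from compound 3 to compound 4 can be read, since both values are limits and not numbers: the limit of > 40000 nM in this assay, at which 4 of the 4 values shown sit.

The compounds shown leave open whether any change to the shared core gives a readable number in this assay, and how large such a change would be.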